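This account rests on a few compounds, and the source may have more. Where it says the series, first, only, none or still open, it means among the compounds named here.

Two compounds share one core, a piperazine urea carrying a benzyl group with a chlorophenoxy substituent, and differ only in the aromatic group on the urea nitrogen. Compound 1 `Cc1nc2cc(NC(=O)N3CCN(Cc4cccc(Oc5ccc(Cl)cc5)c4)CC3)ccc2o1` gives 200 nM in an assay on isolated protein for inhibition of Fatty-acid amide hydrolase 1 (Rattus norvegicus), with a stated time of 60 min; a higher number here means a weaker inhibitor, a lower number a stronger inhibitor. Compound 2 `O=C(Nc1noc2ccncc12)N1CCN(Cc2cccc(Oc3ccc(Cl)cc3)c2)CC1` gives 2200 nM in this assay, the higher of the two numbers, so it is the weaker inhibitor of the pair. Going by the values given here, the one step seen so far, an 11-fold higher number from compound 1 to compound 2 (1.04 log units; beyond the scatter), shows that exchanging this aromatic group can move the number a long way.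

Compound 3 `O=C(Nc1cccn2ccnc12)N1CCN(Cc2cccc(Oc3ccc(Cl)cc3)c2)CC1` is the next variation: a group of 9 heavy atoms (7 carbon, 2 nitrogen; one five-membered aromatic ring with 2 hetero atoms, one six-membered aromatic ring with 1 hetero atom) in place of a group of 9 heavy atoms (6 carbon, 2 nitrogen, 1 oxygen; one five-membered aromatic ring with 2 hetero atoms, one six-membered aromatic ring with 1 hetero atom), on an amide-type nitrogen. Among the compounds with values here, no measured step covers this particular exchange, so the step from compound 1 to compound 2 is only a hint that this position matters, not a guide to direction. On that basis, compound 3 is expected to show a 3.1-fold lower number from compound 2 to compound 3 (0.50 log units; beyond the scatter), with a lower number than compound 2 thought somewhat more likely than a higher one, given that compound 2 gives 2200 nM and compound 1 gives 200 nM. The estimate for compound 3 is 700 nM, with a range from 150 nM to 3500 nM.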

Compound 3, half-maximal inhibitory concentration: 3500 nM
Compound 3: the middle estimate sits 5.0-fold (0.70 log units) below what was measured; the range from low to high includes it.
By their numbers in this assay, from the lowest: compound 1; then compounds 2 and 3 (each within the scatter of the next).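

In this assay, a 1.6-fold higher number from compound 2 to compound 3 (0.20 log units; within the scatter) shows that these two groups of 9 heavy atoms on the amide-type nitrogen cannot be told apart, even though the entering group has no oxygen and counts 2 hydrogen-bond acceptors in place of 3. With an 18-fold higher number from compound 1 to compound 3 (1.24 log units; beyond the scatter), a second large step now stands beside an 11-fold higher number from compound 1 to compound 2 (1.04 log units; beyond the scatter): among these three compounds, both groups with a six-membered aromatic ring with 1 hetero atom give clearly higher numbers than the group of compound 1, whose six-membered aromatic ring is carbon only. Nothing given here explains these differences.

The groups differ in several features at once, so these compounds cannot show whether the nitrogen in the six-membered ring matters on its own or whether other differences between the groups account for the steps. Going by these compounds, it also remains open how the number would move with a plain phenyl group on this amide-type nitrogen, or with a phenyl group carrying an amine or a carboxylic acid.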